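Hydrazone-carbamoyl oxadiazoles: a hydroxyphenyl swap in mice

The source may report more compounds than this note shows. Statements on the series, on what has been measured and on what is new or still open speak of the compounds shown alone.

The measured compounds and their results in a functional assay on the whole organism (strain Swiss albino) with Mus musculus as the target, with a stated time of 4 h (a lower number here means that less compound is needed, a higher number that more compound is needed for the effect), are:
compound 1, `C=C(C)[C@@H]1CC=C(C)/C(=N/NC(=O)Nc2nnc(-c3ccc(F)cc3)o2)C1`, gives 300 mg/kg;
compound 2, `C=C(C)[C@@H]1CC=C(C)/C(=N/NC(=O)Nc2nnc(-c3ccc(O)cc3)o2)C1`, gives 300 mg/kg;
compound 3, `CC(C)=CC/C=C(/C)C/C=N/NC(=O)Nc1nnc(-c2ccc([N+](=O)[O-])cc2)o1`, gives 300 mg/kg.

Compound 3 stands level with compound 1 and compound 2 at the digits shown; none of the three is set apart from the others in this assay. For the measured compounds named here, the one step among the measured compounds, no change at the digits printed from compound 1 to compound 2 (within the scatter), exchanges a substituent on the aromatic ring that hangs from the shared core and leaves the read-out where it was.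

Compound 4, `CC(C)=CC/C=C(/C)C/C=N/NC(=O)Nc1nnc(-c2ccccc2O)o1`, has not yet been tested. It differs from compound 3 in this way: 2-hydroxyphenyl in place of 4-nitrophenyl on an aromatic carbon. Going by the values given here, the change again touches only the aromatic ring on the same position of the core, and the only step that bears on such a change, no change at the digits printed from compound 1 to compound 2 (within the scatter), showed no movement beyond the scatter. The step from compound 3 to compound 4 is therefore expected to be no change at the digits printed from compound 3 to compound 4 (within the scatter), that is, no change beyond the scatter. Compound 4 is thus estimated to give 300 mg/kg in this assay, with a likely range from 150 mg/kg to 600 mg/kg.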

Compound 4, minimum effective dose: 300 mg/kg
The estimate for compound 4 equals the measured number at the digits printed; the measured number falls inside the stated range.
By their numbers in this assay, from the lowest: compounds 1, 2, 3 and 4 (each within the scatter of the next).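

In this assay, replacing 4-nitrophenyl with 2-hydroxyphenyl on the aromatic carbon of the five-membered aromatic ring with 2 nitrogen and 1 oxygen gives no change at the digits printed from compound 3 to compound 4 (within the scatter) and so extends what the earlier step showed at this position. That earlier step exchanged only fluoro for hydroxy on a phenyl ring, whereas here a group of 9 heavy atoms gives way to one of 7, the nitro group is lost, and the ring number of the substituent differs between the two group names. The flat result also now appears with the remainder of the molecule found in compound 3 as well as with that found in compound 1, and none of the four compounds shown goes against it, although the claim reaches no further than these four. The compounds shown leave open whether an amine or a carboxylic acid on the phenyl ring, or a longer alkyl chain in place of that ring, would move the read-out away from this shared level. No accompanying measurement bears on this result.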